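Bromo added to the phenyl of compound 1

This account rests on a few compounds, and the source may have more. Where it says the series, first, only, none or still open, it means among the compounds named here.

Measured so far in an ADME assay on HEK293 cells (Homo sapiens) for antiproliferative activity, read by MTT assay; a higher number here means a weaker inhibitor, a lower number a stronger inhibitor:
compound 1 `Nc1c(C(=O)N/N=C/c2ccccc2)oc2nc(-c3ccccc3)cc(C(F)(F)F)c12` gives 70000 nM
compound 2 `Nc1c(C(=O)NC2CCCC2)oc2nc(-c3cccs3)cc(C(F)(F)F)c12` gives 51000 nM

Compound 1 stands at the higher of the two numbers, but compound 2 sits within the scatter of it, so no order between them can be read. Compound 3 `Nc1c(C(=O)N/N=C/c2ccc(Br)cc2)oc2nc(-c3ccccc3)cc(C(F)(F)F)c12` differs from compound 1 by bromo in place of hydrogen on an aromatic carbon; cut one bond further out, this reads phenyl to 4-bromophenyl. Going by the values given here, no pair of measured compounds covers this change, so for compound 3 a step of a 1.2-fold lower number from compound 1 to compound 3 (0.07 log units; within the scatter) is expected, not beyond the scatter in either direction. Compound 3 is estimated at 60000 nM, with a range from 25000 nM to 150000 nM.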

Compound 3, half-maximal inhibitory concentration: 64000 nM
Estimate against measurement, compound 3: 1.1-fold (0.03 log units) below, within the range that was stated.
By their numbers in this assay, from the lowest: compounds 2, 3 and 1 (each within the scatter of the next).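

In this assay bromo on the aromatic carbon para to a large group gives a 1.1-fold lower number from compound 1 to compound 3 (0.04 log units; within the scatter) and so no readable change: this position takes a single bromine atom with the number staying within the scatter. Going by these compounds alone, the earlier compounds offered no pair differing in one place, so this is the only single-place change that can be read. On these data alone, whether an amine, a carboxylic acid or a longer chain on this same carbon would move the number beyond the scatter stays open. No supporting measurement bears on this result.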